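The source may hold more compounds than are shown below. What is called first, only, known or untested is meant among the compounds shown, and "the series" means these compounds.

Measured compounds:
- compound 1, `COc1ccc([C@H]2OC[C@H]([C@@H](O)c3ccc(OC)c(OC)c3)C[C@@H]2C/C=C/c2ccc(OC)c(OC)c2)cc1`, 46700 nM
- compound 2, `COc1cccc([C@H]2OC[C@H]([C@@H](O)c3ccc(OC)c(OC)c3)C[C@@H]2C/C=C/c2ccc(OC)c(OC)c2)c1`, 21800 nM
- compound 3, `COc1cccc([C@H](O)[C@H]2CO[C@@H](c3ccc(OC)c(OC)c3)[C@H](C/C=C/c3ccc(OC)c(OC)c3)C2)c1`, 18600 nM

In a functional assay on HeLa cells (Homo sapiens) for cytotoxicity, read by WST assay, with a stated time of 48 h (a higher number here means a weaker inhibitor, a lower number a stronger inhibitor), compound 1 gives the highest of the three numbers. Its nearest neighbour is compound 2: a 2.1-fold lower number from compound 1 to compound 2 (0.33 log units; beyond the scatter), the change being a 3-methoxyphenyl in place of a 4-methoxyphenyl on a saturated ring carbon. Within the data shown here, compound 3, with its value of 18600 nM, sits furthest from compound 1, but no single-point step connects the two.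

The compound under consideration here is compound 4, `COc1ccc([C@@H]2OC[C@H]([C@@H](O)c3ccc(OC)c(OC)c3)C[C@H]2C/C=C/c2ccc(OC)c(OC)c2)cc1`. Set against compound 1, the difference is purely one of configuration: the two compounds have the same atoms and bonds and differ only in configuration as drawn: 2 of 5 stereo elements differ; a stereocentre at a saturated ring carbon is drawn S in compound 1 and R in compound 4; a stereocentre at a saturated ring carbon is drawn S in compound 1 and R in compound 4.

Among the measured compounds shown here, none of the measured steps concerns a change of configuration, so nothing indicates how this assay responds to inverting two saturated ring centres; the only step on record, from compound 1 to compound 2, changes a substituent rather than a stereocentre. With no guide, the most defensible expectation is a number near that of compound 1, held with a wide range. Compound 4 is therefore expected to show no change at the digits printed from compound 1 to compound 4 (within the scatter). The estimate for compound 4 is 46700 nM, with a range from 15000 nM to 150000 nM.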

Compound 4, half-maximal inhibitory concentration: 29200 nM
Estimate against measurement, compound 4: 1.6-fold (0.20 log units) above; the range from low to high includes it.
By their numbers in this assay, from the lowest: compounds 3, 2, 4 and 1 (each within the scatter of the next, the first and the last beyond it).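

In this assay, the series now has its first reading of a change in configuration: drawing the two saturated ring carbons as R rather than S gives a 1.6-fold lower number from compound 1 to compound 4 (0.20 log units; within the scatter). At this level of cytotoxicity, the inversion of these two centres together therefore produces no difference that can be told from the scatter, although it cannot show what either centre does alone. The comparison bears on configuration alone: the fact that compounds 1 and 4 differ only in the configuration as drawn

The compounds shown leave open whether the same inversion would matter with a 3-methoxyphenyl in place of the 4-methoxyphenyl, and how the other three stereo elements bear on the number. They also leave open what an amine or a carboxylic acid in place of a methoxy group would do on the shared core.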